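The compounds below may be only part of what the source reports. "The series", "measured", "known", "first", "only" and "open" are said of these compounds alone.

Working notes on the series. Compound 1 `COc1cc2c(Oc3ccc(NC(=O)c4nn(-c5cccc(F)c5)c(=O)c5ccccc45)cc3F)ccnc2cc1OCCCN1CCCC1`, compound 2 `COc1cc2c(Oc3ccc(NC(=O)c4nn(-c5ccc(Br)cc5)c(=O)c5ccccc45)cc3F)ccnc2cc1OCCCN1CCCC1` and compound 3 `COc1cc2c(Oc3ccc(NC(=O)c4nn(-c5ccccc5Br)c(=O)c5ccccc45)cc3F)ccnc2cc1OCCCN1CCCC1` share one core and differ only in the aryl carried on the aromatic nitrogen. In a functional assay on HT-29 cells (Homo sapiens) for cytotoxicity, read by MTT assay, with a stated time of 72 h (a higher number here means a weaker inhibitor, a lower number a stronger inhibitor), compound 1 gives 460 nM, compound 2 gives 670 nM and compound 3 gives 850 nM. The steps of a 1.5-fold higher number from compound 1 to compound 2 (0.16 log units; within the scatter), a 1.8-fold higher number from compound 1 to compound 3 (0.27 log units; within the scatter) and a 1.3-fold higher number from compound 2 to compound 3 (0.10 log units; within the scatter) all stay inside the scatter, so compound 2 is not set apart from either neighbour. Compound 4 `COc1ccc(-n2nc(C(=O)Nc3ccc(Oc4ccnc5cc(OCCCN6CCCC6)c(OC)cc45)c(F)c3)c3ccccc3c2=O)cc1` carries methoxy in place of bromo on an aromatic carbon. For the measured compounds named here, no measured step exchanges a halogen for a methoxy; the three aryl swaps that exist moved nothing beyond the scatter, and they are the only guide. A step of a 1.1-fold lower number from compound 2 to compound 4 (0.03 log units; within the scatter) is therefore expected, inside the scatter. Compound 4 is estimated at 620 nM, with a range from 250 nM to 1600 nM.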

Compound 4, half-maximal inhibitory concentration: 2360 nM
For compound 4 the middle estimate is 3.8-fold (0.58 log units) below the measured one, outside the stated range (above it).
By their numbers in this assay, from the lowest: compounds 1, 2 and 3 (each within the scatter of the next); then compound 4.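

Methoxy in place of bromo gives a 3.5-fold higher number from compound 2 to compound 4 (0.55 log units; beyond the scatter), the first step at this position beyond the scatter, and the other two swaps agree, with a 2.8-fold higher number from compound 3 to compound 4 (0.44 log units; beyond the scatter) and a 5.1-fold higher number from compound 1 to compound 4 (0.71 log units; beyond the scatter). The aryl on the aromatic nitrogen is therefore not indifferent: the three halogen-bearing aryls stay within the scatter of each other, while the 4-methoxyphenyl stands apart from all of them. Nothing available explains this shift.

Only one methoxy compound is shown, so it remains open whether the higher number belongs to methoxy alone or would also come with a hydroxyl or an amine at the same place. From the compounds shown here alone, how methoxy behaves elsewhere on this ring is also open.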